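Swapping 4-methylphenyl for allyl on a shared core

The source may report more compounds than this note shows. Statements on the series, on what has been measured and on what is new or still open speak of the compounds shown alone.

Compound 1 `S=C(N/N=C\c1ccnc2ccccc12)Nc1ccc(Cl)cc1`: 1070 nM
Compound 2 `Cc1ccc(NC(=S)N/N=C\c2ccnc3ccccc23)cc1`: 980 nM
Compound 3 `C=CCNC(=S)N/N=C\c1ccnc2ccccc12`: not yet measured

In a functional assay on MCF7 cells (Homo sapiens) for cytotoxicity, read by MTT assay, with a stated time of 48 h (on this read-out lower numbers stand for stronger inhibition and higher numbers for weaker inhibition), compound 2 gives 980 nM, level within the scatter with compound 1 at 1070 nM. Compound 3 carries allyl in place of 4-methylphenyl on an amide-type nitrogen. Within the data shown here, the only measured step, a 1.1-fold lower number from compound 1 to compound 2 (0.04 log units; within the scatter), bears on this loosely. It is a swap of methyl in place of chloro on an aromatic carbon, and it stays within the scatter. Among the measured compounds shown here, that swap keeps the aromatic ring, whereas compound 3 has none, so no measured step shows what losing the ring does in this assay. A higher number, meaning weaker inhibition, is expected, but this is a judgement and not a measured trend. The estimated step is a 2.0-fold higher number from compound 2 to compound 3 (0.31 log units; beyond the scatter). For compound 3 the estimated value is 2000 nM, with an expected range from 600 nM to 7000 nM.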

Compound 3, half-maximal inhibitory concentration: 970 nM
The estimate for compound 3 lay 2.1-fold (0.31 log units) above the measured number; the range from low to high includes it.
By their numbers in this assay, from the lowest: compounds 3, 2 and 1 (each within the scatter of the next).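

In this assay, allyl in place of 4-methylphenyl on the amide-type nitrogen gives a 1.0-fold lower number from compound 2 to compound 3 (0.00 log units; within the scatter), and allyl in place of 4-chlorophenyl gives a 1.1-fold lower number from compound 1 to compound 3 (0.04 log units; within the scatter). The earlier step changed only a group on the aromatic ring, whereas these two steps remove that ring altogether and leave the number within the scatter, so at this position, for these compounds, the ring is not needed to keep the read-out at this level. No supporting data are available to explain this result.

The three compounds leave open how far this holds: a longer chain, a cyclohexyl ring, or a chain ending in an amine or a carboxylic acid on the same nitrogen might give a different number. From the compounds shown here alone, the part played by the shared core also remains unknown, since it is the same in all three compounds.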